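The source may hold more compounds than are shown below. What is called first, only, known or untested is meant among the compounds shown, and "the series" means these compounds.

Measured compounds and values:
Compound 1 `C#CCSc1cnc2ccccc2c1[Se]CC#CCCl`: 7.1 ug/mL
Compound 2 `OCC#CCSc1cnc2ccccc2c1SCC#CCCl`: 43.4 ug/mL
Compound 3 `OCC#CCSc1cnc2ccccc2c1[Se]CC#CCCl`: 3.8 ug/mL

In a functional assay on B16 cells (Mus musculus) for antiproliferative activity, with a stated time of 72 h (on this read-out higher numbers stand for weaker inhibition and lower numbers for stronger inhibition), compound 2 has the highest number of the three; the nearest is compound 1, and the step from compound 2 to compound 3 is an 11-fold lower number from compound 2 to compound 3 (1.06 log units; beyond the scatter). The untested compound 4 `C#CCSc1cnc2ccccc2c1SCC#CCCl` differs from compound 2 by hydrogen in place of hydroxymethyl on a triple-bonded carbon. For the measured compounds named here, the only measured step that bears on this change is the one from compound 1 to compound 3, a 1.9-fold lower number from compound 1 to compound 3 (0.27 log units; within the scatter), which runs in the opposite direction and stays within the scatter. On that basis the step from compound 2 to compound 4 is expected to be small, if anything toward a higher number, and the expected step is a 1.5-fold higher number from compound 2 to compound 4 (0.18 log units; within the scatter). Compound 4 is therefore estimated at 65 ug/mL, with a range from 30 ug/mL to 150 ug/mL.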

Compound 4, concentration for 50% inhibition: 52.8 ug/mL
The estimate for compound 4 lay 1.2-fold (0.09 log units) above the measured number; measured number inside the range.
By their numbers in this assay, from the lowest: compounds 3 and 1 (each within the scatter of the next); then compounds 2 and 4 (each within the scatter of the next).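

In this assay, the change from hydroxymethyl to hydrogen on the triple-bonded carbon gives a 1.2-fold higher number from compound 2 to compound 4 (0.09 log units; within the scatter), so it now stays within the scatter on the sulfur-bearing core as well as the selenium-bearing one: the same change on two cores in this assay, a 1.9-fold lower number (0.27 log units; within the scatter) from compound 1 to compound 3 and a 1.2-fold lower number (0.09 log units; within the scatter) from compound 4 to compound 2, 1.5-fold (0.19 log units) apart, within the scatter of two such steps. The group carrying sulfur in place of the one carrying selenium gives a 7.4-fold higher number from compound 1 to compound 4 (0.87 log units; beyond the scatter), showing that this exchange also goes beyond the scatter where the triple-bonded carbon carries hydrogen: the same change on two cores in this assay, an 11-fold lower number (1.06 log units; beyond the scatter) from compound 2 to compound 3 and a 7.4-fold lower number (0.87 log units; beyond the scatter) from compound 4 to compound 1, 1.5-fold (0.19 log units) apart, within the scatter of two such steps.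

The compounds shown leave open whether an aminomethyl group or a carboxylic acid on that triple-bonded carbon would also stay within the scatter in this assay. They also leave open whether a longer hydroxyalkyl chain there would do so.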